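The source may hold more compounds than are shown below. What is called first, only, known or untested is meant among the compounds shown, and "the series" means these compounds.

Measured so far:
- compound 1 `COc1ccc(Cn2cc(CSC(=S)N3CCN(C(=O)OCc4ccccc4)CC3)nn2)cc1` — 30500 nM
- compound 2 `Cc1ccc(-n2cc(CSC(=S)N3CCN(C(=O)OC(C)(C)C)CC3)nn2)cc1` — 74200 nM

Both numbers come from a functional assay on MCF7 cells (Homo sapiens) for inhibition, read by MTT assay, with a stated time of 72 h; a lower number here means a stronger inhibitor, a higher number a weaker inhibitor. Compound 2 stands with the highest of the two values; its nearest neighbour, compound 1, sits at a lower number, and that gap is beyond the scatter. The two compounds differ in more than one place, so the gap cannot be tied to any single change; it only shows that compound 1 is the stronger of the pair in this assay.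

Compound 3 `CC(C)(C)OC(=O)N1CCN(C(=S)SCc2cn(Cc3ccccc3Cl)nn2)CC1` is the next compound. Relative to compound 2 the change is 2-chlorobenzyl in place of 4-methylphenyl on an aromatic nitrogen. For the measured compounds named here, no step of this kind between measured compounds exists, so its size has to be guessed. Going by the values given here, the only hint is that compound 1, which also carries a benzyl-type group on the same ring nitrogen, gives the lower number in this assay, although its other difference from compound 2 clouds that reading. A modest move towards a lower number is expected, of a size that may or may not clear the scatter.

Compound 3 is estimated at 45000 nM in this assay, within 15000 nM to 110000 nM. The expected step is a 1.6-fold lower number from compound 2 to compound 3 (0.22 log units; within the scatter).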

Compound 3, half-maximal inhibitory concentration: 6090 nM
Estimate against measurement, compound 3: 7.4-fold (0.87 log units) above, and the stated range ends above it.
By their numbers in this assay, from the lowest: compound 3; then compound 1; then compound 2.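

In this assay, for the compounds shown here, the group on the aromatic nitrogen of the five-membered ring is the first place where a single change can be read, and 2-chlorobenzyl in place of 4-methylphenyl gives a 12-fold lower number from compound 2 to compound 3 (1.09 log units; beyond the scatter). The gap between compound 1 and compound 2 could not be tied to any one place, whereas this large step, beyond the scatter, belongs to this position alone, so the group held there clearly matters in this cell read-out. Going by these compounds alone, nothing measured so far accounts for the size of the step.

The change also bundles several differences into one step: the ring is attached as a benzyl rather than directly as a phenyl, a chlorine enters, and a methyl leaves, so the compounds shown do not say which of these carries the step. A plain benzyl group and a 2-chlorophenyl group on the same nitrogen would pull these apart, while a carboxylic acid or an amine on the aromatic ring, or a longer chain to that ring, would show how far this position can be pushed.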